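A Hydroxy Group Added to a Weak Growth Inhibitor

The compounds below may be only part of what the source reports. "The series", "measured", "known", "first", "only" and "open" are said of these compounds alone.

In a functional assay on SiHa cells (Homo sapiens) for inhibition, read by sulforhodamine B assay (a higher number here means a weaker inhibitor of growth, a lower number a stronger inhibitor of growth), compound 1 (`CN(C)c1ccc(-c2ccc(-c3ccc(-c4nc5ccccc5[nH]4)cc3)cc2)cc1`) gives 100000 nM. Compound 2 (`Clc1cccc(-c2ccc(-c3ccc(-c4nc5ccccc5[nH]4)cc3)cc2)c1`) gives the same number, 100000 nM, and these two share the highest reading of the three measured. Compound 3 (`COc1ccc(-c2ccc(-c3ccc(-c4nc5ccccc5[nH]4)cc3)cc2)cc1OC`) gives 6200 nM, which makes it the strongest inhibitor of growth so far.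

Compound 4 (`CN(C)c1ccc(-c2ccc(-c3ccc(-c4nc5c(O)cccc5[nH]4)cc3)cc2)cc1`) differs from compound 1 in one place: hydroxy in place of hydrogen on an aromatic carbon. This is hydroxy in place of hydrogen on an aromatic carbon, which turns 1H-benzimidazol-2-yl into 4-hydroxy-1H-benzimidazol-2-yl.

Going by the values given here, no measured step tests this change directly. Each one swaps the substituted phenyl group instead, so they bear on it only loosely. They show that a single change to the shared structure can do nothing, as in no change at the digits printed from compound 1 to compound 2 (within the scatter), or a great deal, as in a 16-fold lower number from compound 1 to compound 3 (1.21 log units; beyond the scatter). No step beyond the scatter can therefore be firmly expected. Any real movement in this assay should more likely go to a lower number because compound 1 already gives 100000 nM, the top of the readings so far.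

The estimated step is a 2.0-fold lower number from compound 1 to compound 4 (0.30 log units; within the scatter). Compound 4 is expected to give about 50000 nM, with an estimated range of 7000 nM to 120000 nM.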

Compound 4, concentration for 50% growth inhibition: 6240 nM
Compound 4: middle estimate off by 8.0-fold (0.90 log units), on the high side; measured number below the stated range.
By their numbers in this assay, from the lowest: compounds 3 and 4 (each within the scatter of the next); then compounds 1 and 2 (each within the scatter of the next).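

In this assay, hydroxy in place of hydrogen, which turns 1H-benzimidazol-2-yl into 4-hydroxy-1H-benzimidazol-2-yl, gives a 16-fold lower number from compound 1 to compound 4 (1.20 log units; beyond the scatter) and so moves the reading well beyond the usual scatter. Going by these compounds alone, the earlier steps all swapped the substituted phenyl group, so this is the first sign that the six-membered aromatic ring of carbon only, part of the fused system of two rings, is also a place where one change can matter, and here that change adds just 1 heavy atom, an oxygen. Nothing in the available information explains why this hydroxy has such an effect.

Among the compounds shown, this hydroxy appears only together with the 4-(dimethylamino)phenyl group, so it remains open whether it would lower the number to a similar extent in the 3-chlorophenyl or 3,4-dimethoxyphenyl series. On these data alone, it also remains open whether hydroxy itself is needed at this position, or whether a methoxy group, an amine or a fluorine atom in the same place would give a comparable reading.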